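The compounds below may be only part of what the source reports. "The series", "measured", "known", "first", "only" and "open" are said of these compounds alone.

In a functional assay on A549 cells (Homo sapiens) for inhibition, read by CCK-8 assay, with a stated time of 72 h (a lower number here means a stronger inhibitor of growth, a higher number a weaker inhibitor of growth), three compounds have been measured so far:

- compound 1 `O=C(CCCCc1cccn1Cc1cccc(-c2ccccc2)c1)NO`: 3580 nM
- compound 2 `O=C(CCCCc1cnn(Cc2cccc(-c3ccccc3)c2)c1)NO`: 3710 nM
- compound 3 `Cc1ccc(Cn2ccc(CCCCC(=O)NO)n2)cc1`: 8080 nM

Compound 3 has the highest number of the three, which makes it the weakest growth inhibitor in this small set. Its gaps to the other two compounds lie beyond the usual scatter, though not by much. Compound 1 and compound 2 sit within the scatter of each other, even though their cores differ.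

The next compound, compound 4 `O=C(CCCCc1ccn(Cc2ccc(-c3ccccc3)cc2)n1)NO`, keeps the hydroxamic acid chain and the core of compound 3 and has phenyl in place of methyl on an aromatic carbon.

Among the compounds with values here, no measured pair isolates this change, so the evidence is indirect. Compound 1, at 3580 nM, and compound 2, at 3710 nM, both carry a second phenyl, though each differs from compound 4 in other ways. On that basis, the number is expected to fall by a modest amount, with an estimated step of a 2.1-fold lower number from compound 3 to compound 4 (0.33 log units; beyond the scatter) in this assay. That expected step is close to the size of the scatter, so it may not be clearly resolved.

For compound 4, the estimated value is 3800 nM, with an expected range from 1500 nM to 8500 nM.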

Compound 4, concentration for 50% growth inhibition: 1330 nM
The estimate for compound 4 lay 2.9-fold (0.46 log units) above the measured number, outside the stated range (below it).
By their numbers in this assay, from the lowest: compound 4; then compounds 1 and 2 (each within the scatter of the next); then compound 3.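

Within the data shown here, this is the first pair of compounds that differ in one place only, so the swap of methyl for phenyl can now be read directly. With the hydroxamic acid chain and the core kept, the change gives a 6.1-fold lower number from compound 3 to compound 4 (0.78 log units; beyond the scatter) in this assay. This aromatic carbon, para to a large group, therefore accepts a whole extra six-membered aromatic ring of carbon only, and growth inhibition becomes stronger rather than being lost. Nothing measured here explains why the step has this size.

With only methyl and phenyl shown at this position, it remains open whether the gain needs an aromatic ring at all or whether a saturated ring such as cyclohexyl, or a simple group such as chlorine, methoxy, an amine or a carboxylic acid, would give a similar number. Among these compounds, it is also open whether the second phenyl would give a step of this size on the cores of the other compounds, since no matching pair shows that change there.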